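Fluoro for Methoxy on the Aryl Ring: Expected Solubility

A few compounds are considered here, and "the series" means these few. Any claim that something is new, unique, unknown or untested is made for them only; others in the source may bear on it.

Compound 2 `COc1cccc(-c2csc(Nc3ccccc3F)n2)c1` anchors the comparison. Among the measured compounds shown here, in a physicochemical assay for solubility, using the shake flask method, measured as kinetic solubility, at pH 7.4 (a lower number here means a less soluble compound, a higher number a more soluble compound), compound 2 gives 49300 nM, the only plain number among the two values shown. Compound 1 `Fc1ccccc1Nc1nc(-c2ccccc2)cs1` differs from it only by lacking the methoxy group, and in this assay compound 1 is reported as a limit of < 1000 nM rather than as a number. For the measured compounds named here, the one measured step is an at least 49-fold higher number from compound 1 to compound 2 (1.69 log units; beyond the scatter), methoxy in place of hydrogen on an aromatic carbon; the value of compound 1 sits at the limit of < 1000 nM in this assay, at which 1 of the 2 values shown sits, so the true size of that step is known only as a minimum.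

Compound 3 `Fc1cccc(-c2csc(Nc3ccccc3F)n2)c1` is not yet measured. Its change from compound 2 is fluoro in place of methoxy on an aromatic carbon, on a six-membered aromatic ring of carbon only, meta to a large group. Going by the values given here, the step of an at least 49-fold higher number from compound 1 to compound 2 (1.69 log units; beyond the scatter) bears on this, as it concerns the same methoxy that now leaves; the fluoro that enters has no measured counterpart. Removing the methoxy is expected to reverse much of that large gain, a 9.9-fold lower number from compound 2 to compound 3 (0.99 log units; beyond the scatter). Compound 3 is therefore estimated to give 5000 nM, in the range 1000 nM to 25000 nM.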

Compound 3, solubility: < 1000 nM
Compound 3: only a limit was reported; the forecaster's own chance of this, stated with the estimate: 35%; middle value at least 5.0-fold (0.69 log units) from the limit.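

In this assay, fluoro in place of methoxy on this aromatic carbon gives an at least 49-fold lower number from compound 2 to compound 3 (1.69 log units; beyond the scatter), so the high reading seen with methoxy is not kept by fluoro on this ring. Compound 3 is reported only as a limit, < 1000 nM, and among the compounds shown, a plain number appears only with methoxy in place. The step between compound 1 and compound 3 cannot be read, and hydrogen and fluoro at this place stay unranked, as both compounds rest on the same limit: the limit of < 1000 nM in this assay, at which 2 of the 3 values shown sit.

The compounds shown leave open whether the high reading belongs to methoxy alone or would also appear with an ethoxy, a hydroxyl or an amine on the same carbon, since a single group with a plain number cannot separate these cases. Also open, on these data alone, are the true values of compound 1 and compound 3 and with them the full size of the steps that lead to compound 2, as well as whether methoxy would give a similar reading at another place on the ring.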